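Adding a Methoxy Group to the Fused Ring of Compound 1

This account rests on a few compounds, and the source may have more. Where it says the series, first, only, none or still open, it means among the compounds named here.

Measured so far:
compound 1: `CS(=O)(=O)c1ccc(Nc2ncc(F)c(Nc3nc4ccccc4s3)n2)cc1` — 4980 nM
compound 2: `CS(=O)(=O)c1ccc(Nc2nccc(Nc3nc4ccccc4s3)n2)cc1` — 5910 nM

In a functional assay on MDA-MB-231 cells (Homo sapiens) for antiproliferative activity, read by MTT assay, with a stated time of 48 h (on this read-out higher numbers stand for weaker inhibition and lower numbers for stronger inhibition), compound 1 gives 4980 nM, the lowest of the two numbers seen; its nearest neighbour is compound 2, which in this assay gives 5910 nM. Going by the values given here, the only measured step, a 1.2-fold higher number from compound 1 to compound 2 (0.07 log units; within the scatter), exchanges hydrogen for fluoro on an aromatic carbon of the shared core and stays within the scatter.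

Compound 3, `COc1ccc2nc(Nc3nc(Nc4ccc(S(C)(=O)=O)cc4)ncc3F)sc2c1`, differs from compound 1 by methoxy in place of hydrogen on an aromatic carbon. Among the compounds with values here, no measured step touches this position of the fused ring system, so the one step on record, small as it is, tells little about what a methoxy group there will do. With nothing on record beyond compound 1 and compound 2, the expectation is anchored on compound 1 and kept broad.

Compound 3 is therefore expected to give 4000 nM in this assay, with a range from 1300 nM to 12000 nM. This amounts to an expected step of a 1.2-fold lower number from compound 1 to compound 3 (0.10 log units; within the scatter), one that may well fall inside the scatter.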

Compound 3, half-maximal inhibitory concentration: 4740 nM
Compound 3: middle estimate off by 1.2-fold (0.07 log units), on the low side, within the range that was stated.
By their numbers in this assay, from the lowest: compounds 3, 1 and 2 (each within the scatter of the next).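

In this assay, methoxy in place of hydrogen on this aromatic carbon, meta to a fused ring and para to a fused ring, gives a 1.1-fold lower number from compound 1 to compound 3 (0.02 log units; within the scatter) and so stays within the scatter. Going by these compounds alone, the earlier step concerned only fluoro and hydrogen on the shared core, so this is the first reading from the six-membered aromatic ring of carbon only, and it shows that this carbon can carry methoxy with no step beyond the scatter on this read-out. Nothing on record explains this outcome or shows what else the change may alter in these cells.

From the compounds shown here alone, whether an amine, a carboxylic acid or a longer alkoxy chain on the same carbon would also stay within the scatter remains open, and a single substituent cannot show how far this tolerance extends. Also open, going by these compounds, is whether methoxy on the other carbons of this ring would read the same, and whether methoxy at this carbon would give a similar step on the core of compound 2, which carries hydrogen in place of fluoro.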